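Shortening the Side Chain to a Hydroxyethyl Group

This account rests on a few compounds, and the source may have more. Where it says the series, first, only, none or still open, it means among the compounds named here.

Measured compounds:
Compound 1, `COC(=O)CCCc1onc(NS(=O)(=O)c2ccc(C(C)(C)C)cc2)c1Sc1cccc(OC)c1`, gives 310 nM in an assay on COS-7 cells for displacement of a labelled ligand from Endothelin receptor type B (Sus scrofa); a lower number here means a stronger inhibitor, a higher number a weaker inhibitor.
Compound 2, `COc1cccc(Sc2c(NS(=O)(=O)c3ccc(C(C)(C)C)cc3)noc2CCCC#N)c1`, gives 520 nM in this assay.

Among the measured compounds shown here, compound 2 has the highest of the two numbers, but its nearest neighbour, compound 1, lies close: the one step known between them, a 1.7-fold higher number from compound 1 to compound 2 (0.22 log units; within the scatter), is within the scatter, so the two cannot be ranked. The unmeasured compound 3, `COc1cccc(Sc2c(NS(=O)(=O)c3ccc(C(C)(C)C)cc3)noc2CCO)c1`, differs from compound 2 by hydroxy in place of cyanomethyl on a saturated chain carbon, two bonds along the chain from an aromatic carbon. For the measured compounds named here, no measured step covers this exact change; the single step from compound 1 to compound 2 only shows that swapping the group at the end of the chain left the number within the scatter. Shortening the chain itself has no precedent among these compounds, so the outlook rests on a weak base. Compound 3 is therefore expected to land near compound 2, with the step of a 1.2-fold higher number from compound 2 to compound 3 (0.06 log units; within the scatter) expected to stay within the scatter but with wide uncertainty either way. The estimate for compound 3 is 600 nM, ranging from 200 nM to 2000 nM.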

Compound 3, half-maximal inhibitory concentration: 430 nM
For compound 3 the middle estimate is 1.4-fold (0.14 log units) above the measured one; the measured number falls inside the stated range.
By their numbers in this assay, from the lowest: compounds 1, 3 and 2 (each within the scatter of the next).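

In this assay, putting hydroxy in place of cyanomethyl gives a 1.2-fold lower number from compound 2 to compound 3 (0.08 log units; within the scatter), and putting hydroxy in place of (methoxycarbonyl)methyl gives a 1.4-fold higher number from compound 1 to compound 3 (0.14 log units; within the scatter). The earlier pair only showed that one end group could replace another on a chain of the same length, whereas here the chain is shorter and the new end group carries a hydrogen-bond donor, yet all three compounds remain within the scatter and cannot be ranked, so at this position, on a saturated chain carbon, two bonds along the chain from an aromatic carbon, the change from 3-cyanopropyl to 2-hydroxyethyl leaves no measurable mark on the number in this comparison. No independent measurement is available to say why the number holds through this change.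

Chain length and end group change together here, so the compounds shown cannot separate the two, and a 3-hydroxypropyl chain would be the direct test of length alone. Going by these compounds, it also remains open whether a charged-capable end such as an amine or a carboxylic acid on this chain, or a much longer chain, would stay within the same range.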